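This account rests on a few compounds, and the source may have more. Where it says the series, first, only, none or still open, it means among the compounds named here.

Compound 1 `COc1cc(-c2nnc(SCc3ccc(C)cc3)o2)ccc1O` gives 6210 nM in a functional assay on cells (T-cell, Mus musculus, strain BALB/c) for inhibition, read by MTT assay, with stated times of 24 h and 72 h; a higher number here means a weaker inhibitor, a lower number a stronger inhibitor.
Compound 2 `COc1cc(-c2nnc(SCc3c(F)cccc3F)o2)ccc1O` gives 10100 nM in this assay.

Compound 2 stands at the highest of these two numbers, but the step of a 1.6-fold higher number from compound 1 to compound 2 (0.21 log units; within the scatter) lies within the scatter, so the two compounds cannot be told apart. Compound 3 `COc1cc(-c2nnc(SCc3ccccc3Br)o2)ccc1O` differs from compound 2 by 2-bromophenyl in place of 2,6-difluorophenyl on a saturated chain carbon bound to a sulfur. Going by the values given here, the only measured step bearing on it, a 1.6-fold higher number from compound 1 to compound 2 (0.21 log units; within the scatter), exchanged the group on the saturated chain carbon bound to a sulfur without moving the number beyond the scatter. No step beyond the scatter is therefore expected for a 1.3-fold lower number from compound 2 to compound 3 (0.10 log units; within the scatter). Compound 3 is estimated at 8000 nM, within a range from 3000 nM to 25000 nM.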

Compound 3, half-maximal inhibitory concentration: 17800 nM
The estimate for compound 3 lay 2.2-fold (0.35 log units) below the measured number; the range from low to high includes it.
By their numbers in this assay, from the lowest: compounds 1, 2 and 3 (each within the scatter of the next, the first and the last beyond it).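

Replacing 2,6-difluorophenyl with 2-bromophenyl does not separate the two compounds (a 1.8-fold higher number from compound 2 to compound 3 (0.25 log units; within the scatter)). Set against 4-methylphenyl, however, 2-bromophenyl gives the first step here that clears the scatter (a 2.9-fold higher number from compound 1 to compound 3 (0.46 log units; beyond the scatter)), so the group on the saturated chain carbon bound to a sulfur can shift the number, if only modestly. No measurement shown explains this shift.

All three groups are substituted phenyl rings. As far as these compounds go, whether an amine, a carboxylic acid or a longer chain at this place would give a number lower than that of compound 1 remains open.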